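From ethyl to 4-methylphenyl on an aromatic nitrogen

A few compounds are considered here, and "the series" means these few. Any claim that something is new, unique, unknown or untested is made for them only; others in the source may bear on it.

In a functional assay on T47D cells (Homo sapiens) for antiproliferative activity, read by MTT assay, with a stated time of 72 h (a lower number here means a stronger inhibitor, a higher number a weaker inhibitor), compound 1 `CCn1ccnc1-c1cc(OC)c(OC)c(OC)c1` gives > 100000 nM as a limit and not a number. Compound 2 `COc1cc(-c2nccn2-c2ccc3[nH]ccc3c2)cc(OC)c1OC` gives a measured 2100 nM in this assay on the same read-out. Compound 3 `COc1cc(-c2nccn2-c2ccc(C)cc2)cc(OC)c1OC` has 4-methylphenyl in place of ethyl on an aromatic nitrogen and awaits measurement. For the measured compounds named here, no measured step covers this change, but compound 2 at 2100 nM shows that a measurable value can be reached, so a gain beyond the scatter is expected. The estimated step of an at least 20-fold lower number from compound 1 to compound 3 (1.30 log units; beyond the scatter) is expected to run toward stronger inhibition. Compound 3 is expected at 5000 nM within a range of 800 nM to 40000 nM by this estimate.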

Compound 3, half-maximal inhibitory concentration: 20500 nM
Beside the measured number, compound 3's estimate is 4.1-fold (0.61 log units) below it, within the range that was stated.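

At this aromatic nitrogen, 4-methylphenyl in place of ethyl brings the compound into a measurable range in this assay, the change giving an at least 4.8-fold lower number from compound 1 to compound 3 (0.68 log units; beyond the scatter). Compound 1 stands at a limit and not a number, so the full size of this step cannot be read: the limit of > 100000 nM in this assay, at which 1 of the 3 values shown sits.

This single change does not separate the effect of the aromatic ring from that of the added carbons, and a benzyl or unsubstituted phenyl group would bear on that. Going by these compounds, whether an amine or a carboxylic acid in place of the methyl of the 4-methylphenyl would shift the value also remains open.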